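Hydroxyphenyl placement across two related cores

This account rests on a few compounds, and the source may have more. Where it says the series, first, only, none or still open, it means among the compounds named here.

Compound 1 `Oc1cccc(-c2cc(-c3cccc(C(F)(F)F)c3)cc(-c3ccccc3O)n2)c1` gives 6460 nM in a functional assay on HCT-15 cells (Homo sapiens) for inhibition; on this read-out lower numbers stand for stronger inhibition and higher numbers for weaker inhibition. Compound 2 `Oc1cccc(-c2cc(-c3cccc(C(F)(F)F)c3)cc(-c3cccc(O)c3)n2)c1` gives 13600 nM in this assay. The change 3-hydroxyphenyl in place of 2-hydroxyphenyl on an aromatic carbon produced a 2.1-fold higher number from compound 1 to compound 2 (0.32 log units; beyond the scatter). Compound 3 `Oc1ccccc1-c1cc(-c2ccccc2OC(F)(F)F)cc(-c2ccccc2O)n1` gives 4520 nM in this assay; it carries the lowest number of the three measured, but its gap to compound 1 lies within the scatter, while compound 2 lies beyond it. The difference between the core of compound 1 and the core of compound 3 is not broken down here.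

Compound 4 `Oc1cccc(-c2cc(-c3ccccc3OC(F)(F)F)cc(-c3ccccc3O)n2)c1` has not been measured in this assay. It differs from compound 3 by 3-hydroxyphenyl in place of 2-hydroxyphenyl on an aromatic carbon. This is the same kind of change as that from compound 1 to compound 2, though the surroundings differ: here the place is meta to a 2-hydroxyphenyl group and meta to a large group, whereas earlier it was meta to a 3-(trifluoromethyl)phenyl group and meta to a 3-hydroxyphenyl group. For compound 4 the step is estimated as a 2.1-fold higher number from compound 3 to compound 4 (0.32 log units; beyond the scatter), because the same kind of change gave a 2.1-fold higher number from compound 1 to compound 2 (0.32 log units; beyond the scatter). Compound 4 is therefore expected to give 9500 nM, between 5000 nM and 18000 nM.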

Compound 4, half-maximal inhibitory concentration: 3240 nM
Beside the measured number, compound 4's estimate is 2.9-fold (0.47 log units) above it; measured number outside the range, below it.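

On the core of compound 3, 3-hydroxyphenyl in place of 2-hydroxyphenyl gives a 1.4-fold lower number from compound 3 to compound 4 (0.14 log units; within the scatter) in this assay, so no effect of the swap can be read on this core. The step seen on the core of compound 1 therefore does not carry over to the core of compound 3 in this assay, and the two steps differ by more than repeat measurements would explain: the same change on two cores in this assay, a 2.1-fold higher number (0.32 log units; beyond the scatter) from compound 1 to compound 2 and a 1.4-fold lower number (0.14 log units; within the scatter) from compound 3 to compound 4, 2.9-fold (0.47 log units) apart, beyond the scatter of two such steps

This shows that, in these two pairs, the outcome of the swap depends on the core, but it does not show which feature of the two cores is responsible or how the swap would behave on any further core. Within the data shown here, with only two pairs in hand, no general rule for this change can be stated for the series. From the compounds shown here alone, it remains open whether the swap would hold on a core carrying an amine or a carboxylic acid on the aryl group, and whether either group could stand in place of the hydroxyl itself.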